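Swapping an indolyl for a cyclohexyl on a pyridinone amide

This account rests on a few compounds, and the source may have more. Where it says the series, first, only, none or still open, it means among the compounds named here.

Measured compounds:
compound 1 `CNC(=O)c1cc(C(=O)NC2CC2)cn(Cc2cccc3[nH]ccc23)c1=O` — 2.9
compound 2 `CNC(=O)c1cc(C(=O)NC)c(=O)n(Cc2ccccc2)c1` — 2.4
compound 3 `CCNC(=O)c1cccn(Cc2ccccc2)c1=O` — 3.7

In a physicochemical assay for lipophilicity, at pH 7.4 (on this read-out lower numbers stand for lower lipophilicity and higher numbers for higher lipophilicity), compound 1 gives 2.9, the second highest of the three numbers; compound 2 lies below it beyond the scatter and compound 3 lies above it beyond the scatter. Compound 4 `CNC(=O)c1cc(C(=O)NC2CC2)cn(CC2CCCCC2)c1=O` has not yet been measured. It differs from compound 1 in one place: cyclohexyl in place of 1H-indol-4-yl on a saturated chain carbon bound to an aromatic nitrogen. Among the compounds with values here, no pair of measured compounds shares this change, so no measured step tells what to expect. On the basis of compound 1 at 2.9 and the change described, a rise beyond the scatter seems likely in this assay, estimated as a number 0.70 log units higher from compound 1 to compound 4 (beyond the scatter). Compound 4 is expected to give about 3.6, within a range of 3 to 4.2.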

Compound 4, distribution coefficient: 4
Beside the measured number, compound 4's estimate is 0.40 log units below it; the measured number falls inside the stated range.
By their numbers in this assay, from the lowest: compound 2; then compound 1; then compounds 3 and 4 (each within the scatter of the next).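

In this assay, replacing 1H-indol-4-yl with cyclohexyl on a saturated chain carbon bound to an aromatic nitrogen gives a number 1.10 log units higher from compound 1 to compound 4 (beyond the scatter), a large step. Within the data shown here, this is the first measured step at this position, and it shows that the read-out can move strongly here, even with a group carrying fewer heavy atoms. Nothing shown explains the size of this step. Still open, as far as these compounds go, is what an amine or a carboxylic acid on this chain would give. Also open, from the compounds shown here alone, is whether the step would hold with other amides on the shared core.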